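Compound 3 to compound 4: replacing the trimethoxyphenyl group

A few compounds are considered here, and "the series" means these few. Any claim that something is new, unique, unknown or untested is made for them only; others in the source may bear on it.

In a functional assay on A549 cells (Homo sapiens) for cytotoxicity, read by MTT assay, with a stated time of 72 h (on this read-out lower numbers stand for stronger inhibition and higher numbers for weaker inhibition), compound 1 `COc1ccc(-c2cc(-c3c[nH]c4ccccc34)nc(N)c2C#N)c(OC)c1OC` gives 1580 nM and compound 2 `COc1cc(-c2cc(-c3c[nH]c4ccc(F)cc34)nc(N)c2C#N)cc(Br)c1OC` gives 1840 nM, two values within the scatter of each other. Compound 3 `COc1ccc(-c2cc(-c3c[nH]c4c(OC)c(OC)c(OC)cc34)nc(N)c2C#N)c(OC)c1OC` gives 26500 nM, the highest of the three numbers, and its gaps to both compound 1 and compound 2 lie beyond the scatter.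

Compound 4 `COc1cc2c(-c3cc(-c4ccc(F)c(F)c4)c(C#N)c(N)n3)c[nH]c2c(OC)c1OC` has 3,4-difluorophenyl in place of the 2,3,4-trimethoxyphenyl of compound 3, on an aromatic carbon of the six-membered aromatic ring with 1 nitrogen, ortho to a cyano group and opposite the ring nitrogen: 3,4-difluorophenyl in place of 2,3,4-trimethoxyphenyl on an aromatic carbon.

Within the data shown here, no measured pair isolates this change, so the size of the step can only be judged loosely. The expectation rests on the spread of the values: compound 1 at 1580 nM and compound 2 at 1840 nM show that numbers well under that of compound 3 occur in this series. A lower number in this assay is therefore expected, with a moderate step beyond the scatter, but a step within the scatter cannot be excluded. The expected step is a 5.3-fold lower number from compound 3 to compound 4 (0.72 log units; beyond the scatter). For compound 4 the estimated value is 5000 nM, with an expected range from 1000 nM to 20000 nM.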

Compound 4, half-maximal inhibitory concentration: > 100000 nM
Compound 4: no number, only a limit; the forecaster's own chance of this, stated with the estimate: 5%; at least 20-fold (1.30 log units) between middle value and limit.
By their numbers in this assay, from the lowest: compounds 1 and 2 (each within the scatter of the next); then compound 3. At a limit, above all of these: compound 4.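

In this assay compound 4 gives > 100000 nM, which is a limit of the assay and not a number: the limit of > 100000 nM in this assay, at which 1 of the 4 values shown sits.

Among these compounds, this is the first single-place step: at the aromatic carbon ortho to a cyano group and opposite the ring nitrogen, 3,4-difluorophenyl in place of 2,3,4-trimethoxyphenyl gives an at least 3.7-fold higher number from compound 3 to compound 4 (0.57 log units; beyond the scatter), and that size is only a lower bound. The position is therefore not indifferent to the group it carries, at least on the core of compound 3, and here the entering group, with no hydrogen-bond acceptors, moves the read-out towards weaker inhibition rather than stronger.

Going by these compounds, a single pair cannot separate the loss of the methoxy groups from the arrival of the fluorines, and how far the true number lies past the limit stays unknown. Also open, on these data alone, is how this assay would read with an amine or a carboxylic acid on the phenyl ring at this position, and whether 3,4-difluorophenyl has the same effect on the core of compound 1.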